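The source may hold more compounds than are shown below. What is called first, only, known or untested is meant among the compounds shown, and "the series" means these compounds.

Measured so far in an ADME assay on microsomes from liver (Homo sapiens) for pharmacokinetics, read by LC-MS, using NADPH, with a stated time of 45 min, tested at 1 uM; on this read-out higher numbers stand for fast clearance and lower numbers for slow clearance:

- compound 1 `COc1cc(OCc2ccnc(N)n2)cc2sc(N[C@@H]3CCCC[C@H]3O)nc12` gives 10 mL/min/kg
- compound 2 `COc1cc(OCc2ccnc(N)n2)cc2sc(N[C@H]3CCCC[C@@H]3O)nc12` gives 9.5 mL/min/kg
- compound 3 `COc1cc(OCc2ccnc(N)n2)c(Cl)c2sc(N[C@H]3CCCC[C@@H]3O)nc12` gives 33 mL/min/kg

Compound 2 sits at the low end of these numbers, level with its mirror image (a 1.1-fold lower number from compound 1 to compound 2 (0.02 log units; within the scatter)). Putting chloro in place of hydrogen on an aromatic carbon gives a clearly higher number (a 3.5-fold higher number from compound 2 to compound 3 (0.54 log units; beyond the scatter)).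

The next compound is compound 4 `COc1cc(OCc2ccnc(Nc3cnoc3)n2)cc2sc(N[C@H]3CCCC[C@@H]3O)nc12`, which keeps the core of compound 2 with one change: 1,2-oxazol-4-yl in place of hydrogen on a nitrogen on an aromatic ring. Here 1,2-oxazol-4-yl replaces hydrogen on a nitrogen on an aromatic ring, turning amino into (1,2-oxazol-4-yl)amino.

The mirror-image pair says nothing about this change. Compound 3 is the only measured case of a group replacing hydrogen on the core of compound 2, though on a carbon rather than a nitrogen (a 3.5-fold higher number from compound 2 to compound 3 (0.54 log units; beyond the scatter)), so it is a loose guide at best. On that slim basis, a modest rise in this assay is expected, with an estimated 1.9-fold higher number from compound 2 to compound 4 (0.28 log units; within the scatter). For compound 4 the estimate is 18 mL/min/kg, with an expected range from 8 mL/min/kg to 40 mL/min/kg.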

Compound 4, clearance: 61 mL/min/kg
Estimate against measurement, compound 4: 3.4-fold (0.53 log units) below, outside the stated range (above it).
By their numbers in this assay, from the lowest: compounds 2 and 1 (each within the scatter of the next); then compounds 3 and 4 (each within the scatter of the next).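

The amino group of compound 2 is a place where this assay responds: in this assay, putting 1,2-oxazol-4-yl in place of hydrogen on that nitrogen gives a 6.4-fold higher number from compound 2 to compound 4 (0.81 log units; beyond the scatter), which points to faster clearance. For the compounds shown here, this is the first measured change on this nitrogen, as the earlier compounds differ only in configuration or on an aromatic carbon, so they could not show that a substituent here moves the number. Why the number goes up is not explained by anything measured here.

From the compounds shown here alone, it remains open whether the rise belongs to this particular ring or would follow from any group on this nitrogen. A methyl, an acetyl or a plain phenyl ring in the same place would help to separate those two readings.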